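The compounds below may be only part of what the source reports. "The series", "measured", "known", "first", "only" and "open" are said of these compounds alone.

Measured compounds:
compound 1, `Cc1ccccc1Cn1cc(COc2ccc3c(=O)ccoc3c2)nn1`: > 100000 nM in a functional assay on A549 cells (Homo sapiens) for cytotoxicity, read by MTT assay, with a stated time of 48 h; a lower number here means a stronger inhibitor, a higher number a weaker inhibitor
compound 2, `CC(C)(C)c1ccc(Cn2cc(COc3ccc4c(=O)ccoc4c3)nn2)cc1`: > 100000 nM in this assay

Compound 1 stands at a limit of the assay, not at a number: its value of > 100000 nM in this assay only says that no half-maximal inhibition was reached within the tested range. Compound 2 sits at the same kind of limit with > 100000 nM in this assay. Going by the values given here, the whole picture so far is summed up by the limit of > 100000 nM in this assay, at which 2 of the 2 values shown sit; no pair of measured compounds differing in a single place is available, so no measured step can be read.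

Compound 3, `O=c1ccoc2cc(OCc3cn(Cc4cccc(Cl)c4)nn3)ccc12`, differs from compound 1 by 3-chlorophenyl in place of 2-methylphenyl on a saturated chain carbon bound to an aromatic nitrogen. Both values shown rest at the limit (the limit of > 100000 nM in this assay, at which 2 of the 2 values shown sit), so the step from compound 1 to compound 3 is expected to be a number no higher from compound 1 to compound 3 (the limit leaves the size open), that is, no movement beyond the scatter in either direction. Compound 3 is therefore estimated at 100000 nM in this assay, with a plausible range from 40000 nM to 300000 nM, and it is likely that this assay again reports only a limit for compound 3.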

Compound 3, half-maximal inhibitory concentration: 13700 nM
For compound 3 the middle estimate is 7.3-fold (0.86 log units) above the measured one; the whole stated range lies above it.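

In this assay, replacing 2-methylphenyl with 3-chlorophenyl on a saturated chain carbon bound to an aromatic nitrogen gives an at least 7.2-fold lower number from compound 1 to compound 3 (0.86 log units; beyond the scatter), which shows that a change at this position alone can bring the read-out within the tested range. The two groups have the same number of heavy atoms and the same six-membered aromatic ring of carbon, and neither carries a hydrogen-bond donor or acceptor, so those counts do not separate them, while the step still lies beyond the scatter. Compound 3 therefore gives the series its first real number, while the other values remain limits: the limit of > 100000 nM in this assay, at which 2 of the 3 values shown sit.

From the compounds shown here alone, the true size of the step remains open, since the value of compound 1 is a limit and not a number, and the step also changes both the substituent and its place on the phenyl ring, which this single pair cannot pull apart. A 2-chlorophenyl or 3-methylphenyl group would address that question, while the effect of an amine or a carboxylic acid on the same ring is also unknown.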